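One More Carbon on the Chain: Compound 4 Predicted

The compounds below may be only part of what the source reports. "The series", "measured", "known", "first", "only" and "open" are said of these compounds alone.

Measured compounds:
Compound 1 `CCC[C@@H]1O[C@H](COCc2ccccc2)[C@@H](OCc2ccccc2)[C@H](OCc2ccccc2)[C@H]1O`: 38600 nM
Compound 2 `CCCC[C@@H]1O[C@H](COCc2ccccc2)[C@@H](OCc2ccccc2)[C@H](OCc2ccccc2)[C@H]1O`: 40100 nM
Compound 3 `CC[C@@H]1O[C@H](COCc2ccccc2)[C@@H](OCc2ccccc2)[C@H](OCc2ccccc2)C1=O`: 4300 nM

All three were tested in a functional assay on HOS cells (Homo sapiens) for antiproliferative activity, read by sulforhodamine B assay; on this read-out lower numbers stand for stronger inhibition of growth and higher numbers for weaker inhibition of growth. Compound 1 and compound 2 differ only by methyl in place of hydrogen on a saturated chain carbon, three bonds along the chain from a saturated ring carbon. That change gave a 1.0-fold higher number from compound 1 to compound 2 (0.02 log units; within the scatter), so the two compounds read the same within the noise of the measurement. Compound 3 rests on a different core; the difference between the core of compound 3 and the core of compound 1 is not broken down here. Compound 3 gives the lowest number of the three, and its gaps to compound 1 and to compound 2 both lie beyond the scatter.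

Compound 4 `CCC[C@@H]1O[C@H](COCc2ccccc2)[C@@H](OCc2ccccc2)[C@H](OCc2ccccc2)C1=O` is not yet measured. It differs from compound 3 by methyl in place of hydrogen on a saturated chain carbon, two bonds along the chain from a saturated ring carbon. Among the compounds with values here, this is the same kind of change as the one from compound 1 to compound 2, though here the place is two bonds along the chain from a saturated ring carbon rather than three. Because the earlier step gave a 1.0-fold higher number from compound 1 to compound 2 (0.02 log units; within the scatter), a similarly small step is expected, a 1.0-fold higher number from compound 3 to compound 4 (0.02 log units; within the scatter). Compound 4 is therefore estimated at 4500 nM, expected to fall between 2000 nM and 10000 nM.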

Compound 4, concentration for 50% growth inhibition: > 50000 nM
Compound 4 ended at the assay's limit; the forecaster's own chance of this, stated with the estimate: 0%; at least 11-fold (1.04 log units) between middle value and limit.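

In this assay, compound 4 gives > 50000 nM, which is a limit of the assay and not a number: the limit of > 50000 nM in this assay, at which 1 of the 4 values shown sits.

Methyl in place of hydrogen gave an at least 11-fold higher number from compound 3 to compound 4 (1.06 log units; beyond the scatter), so the near absence of change seen on the core of compound 1 did not carry over to this core: the same change on two cores in this assay, a 1.0-fold higher number (0.02 log units; within the scatter) from compound 1 to compound 2 and an at least 11-fold higher number (1.06 log units; beyond the scatter) from compound 3 to compound 4, at least 11-fold (1.04 log units) apart, beyond the scatter of two such steps

Within the data shown here, this shows that, in this series, the result of adding this methyl on one core cannot simply be transferred to another, but it does not show why: each core offers only a single pair, and the methyl sits two bonds along the chain from a saturated ring carbon in one pair and three bonds along in the other, so the effect of the core and the effect of the place cannot be told apart.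

The compounds shown leave open how the step from ethyl to propyl would read on the core of compound 1. Also open, going by these compounds, is how a longer chain, such as pentyl, or an amine on the chain would read on the core of compound 3.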